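The source may report more compounds than this note shows. Statements on the series, on what has been measured and on what is new or still open speak of the compounds shown alone.

Measured in a physicochemical assay for solubility, read by spectrophotometry, in phosphate buffer, with a stated time of 2 h, at pH 7.4; on this read-out higher numbers stand for higher solubility and lower numbers for lower solubility:
compound 1, `COc1ccc2[nH]c(C(=O)N3CC(=O)N(Cc4ccccc4)[C@@H](CN4CCC5(CC4)CC5)C3)cc2c1`: 28200 nM
compound 2, `COc1ccc2[nH]c(C(=O)N3CC(=O)N(Cc4cccc(OC)n4)[C@@H](Cc4ccccc4)C3)cc2c1`: 47500 nM
compound 3, `COc1ccc2[nH]c(C(=O)N3CC(=O)N(Cc4cc5ccccc5[nH]4)[C@@H](Cc4ccccc4)C3)cc2c1`: 11000 nM

Among these three, compound 1 stands second highest in this assay; its number lies within the usual scatter of compound 2, and only compound 3, with a lower number, lies beyond it. Within the data shown here, the one measured step, a 4.3-fold lower number from compound 2 to compound 3 (0.64 log units; beyond the scatter), concerns a different place, on a saturated chain carbon bound to an amide-type nitrogen in a ring, and so says little about the change considered here. Compound 4, `COc1ccc2[nH]c(C(=O)N3CC(=O)N(Cc4ccccc4)[C@@H](CN4CC5CC5C4)C3)cc2c1`, differs from compound 1 by a group of 6 heavy atoms (5 carbon, 1 nitrogen; one three-membered non-aromatic ring of carbon only, one five-membered non-aromatic ring with 1 hetero atom) in place of a group of 8 heavy atoms (7 carbon, 1 nitrogen; one three-membered non-aromatic ring of carbon only, one six-membered non-aromatic ring with 1 hetero atom), on a saturated chain carbon bound to a saturated ring carbon. Among the measured compounds shown here, no measured step shows how this change moves the number in this assay, so no step beyond the scatter is expected. The step from compound 1 to compound 4 is estimated as a 1.2-fold higher number from compound 1 to compound 4 (0.09 log units; within the scatter). Compound 4 is expected to give 35000 nM in this assay, between 17000 nM and 72000 nM.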

Compound 4, solubility: 17500 nM
Estimate against measurement, compound 4: 2.0-fold (0.30 log units) above; low and high end bracket the measured number.
By their numbers in this assay, from the lowest: compounds 3, 4, 1 and 2 (each within the scatter of the next, the first and the last beyond it).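

Among these compounds, at this place, on a saturated chain carbon bound to a saturated ring carbon, the earlier compounds offered no step to read. In this assay, the group of 6 heavy atoms in place of the group of 8 heavy atoms gives a 1.6-fold lower number from compound 1 to compound 4 (0.21 log units; within the scatter) and so provides the first reading, one that stays inside the usual scatter. Nothing measured here accounts for this result. Still open, as far as these compounds go, is whether a morpholine or an open-chain diethylamine at this place would give a step beyond the scatter. One pair also cannot show whether the same exchange would behave alike on another compound.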